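A 4-ethylpiperazin-1-yl group replaces (4-methylbenzyl)amino

The source may report more compounds than this note shows. Statements on the series, on what has been measured and on what is new or still open speak of the compounds shown alone.

In a functional assay on HT-29 cells (Homo sapiens) for inhibition, read by MTT assay, with a stated time of 72 h (on this read-out higher numbers stand for weaker inhibition and lower numbers for stronger inhibition), compound 1 `COc1ccc(CNCc2c(OC)cc(Oc3cccc(Nc4ccccc4)c3)cc2OC)cc1` gives 1890 nM and compound 2 `COc1cc(Oc2cccc(Nc3ccccc3)c2)cc(OC)c1CNCc1ccc(C)cc1` gives 3880 nM, the higher of the two numbers. Compound 3 `CCN1CCN(Cc2c(OC)cc(Oc3cccc(Nc4ccccc4)c3)cc2OC)CC1` carries 4-ethylpiperazin-1-yl in place of (4-methylbenzyl)amino on a saturated chain carbon bound to an aromatic carbon. Among the measured compounds shown here, the only measured step, a 2.1-fold higher number from compound 1 to compound 2 (0.31 log units; beyond the scatter), is modest and concerns methyl in place of methoxy on an aromatic carbon, so it bears only loosely on this change. No clear step beyond the scatter is therefore expected in this assay. The expected step is a 1.3-fold lower number from compound 2 to compound 3 (0.11 log units; within the scatter). Compound 3 is estimated at 3000 nM, with an expected range of 1000 nM to 9000 nM.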

Compound 3, half-maximal inhibitory concentration: > 20000 nM
Compound 3 gave a limit, no number (the forecaster's own chance of this, stated with the estimate: 10%); middle value at least 6.6-fold (0.82 log units) away from the limit.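

In this assay compound 3 gives > 20000 nM, a limit of the assay and not a number. The earlier compounds shown here varied only the group on the benzyl ring, whereas this change replaces the whole amine on the saturated chain carbon bound to an aromatic carbon, and that weighs far more: an at least 5.1-fold higher number from compound 2 to compound 3 (0.71 log units; beyond the scatter), and an at least 10-fold higher number from compound 1 to compound 3 (1.02 log units; beyond the scatter). The compounds shown leave open whether the loss follows from the piperazine ring, the ethyl on it or the missing benzyl ring. A morpholine or a 4-benzylpiperazin-1-yl group at this place would help to separate these.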